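A few compounds are considered here, and "the series" means these few. Any claim that something is new, unique, unknown or untested is made for them only; others in the source may bear on it.

Going by the values given here, the three compounds measured so far share one core and differ only in the group carried on a single saturated ring carbon: compound 1 `Cc1nn(-c2ncnc3nc[nH]c23)c2c1C(c1ccc(OC(C)C)cc1)CC(=O)N2`, compound 2 `Cc1nn(-c2ncnc3nc[nH]c23)c2c1C(OCc1ccccc1Cl)CC(=O)N2` and compound 3 `Cc1nn(-c2ncnc3nc[nH]c23)c2c1C(C(=O)NCc1ccccc1)CC(=O)N2`. In a functional assay on HEK293 cells for agonist activity at G-protein coupled receptor 39 (Homo sapiens), read by scintillation proximity assay and inositol phosphate accumulation, with a stated time of 75 min (on this read-out higher numbers stand for an effect only at larger amounts of compound and lower numbers for an effect already at smaller amounts), compound 1 gives 2700 nM, compound 2 gives 47 nM and compound 3 gives 2930 nM. Compound 2 thus stands lowest of the three numbers, set well apart by the step of a 57-fold lower number from compound 1 to compound 2 (1.76 log units; beyond the scatter) and by the step of a 62-fold higher number from compound 2 to compound 3 (1.79 log units; beyond the scatter), whereas a 1.1-fold higher number from compound 1 to compound 3 (0.04 log units; within the scatter).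

Compound 4 `COc1ccc(CCOC2CC(=O)Nc3c2c(C)nn3-c2ncnc3nc[nH]c23)cc1` keeps the oxygen on a saturated carbon of compound 2 and changes what hangs from it: 4-methoxybenzyl in place of 2-chlorophenyl on a saturated chain carbon bound to an oxygen on a saturated carbon. Going by these compounds, the two large steps above show that the group on this saturated ring carbon can move the number over a wide span, but neither of them varies the aromatic ring while keeping that oxygen, so the new group is untested. Because compound 2 already gives 47 nM, some loss on swapping the ring is more likely than a gain, but it is expected to stay modest, around a 3.2-fold higher number from compound 2 to compound 4 (0.50 log units; beyond the scatter). Compound 4 is therefore estimated at 150 nM, with a likely range from 40 nM to 600 nM.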

Compound 4, half-maximal effective concentration: 70 nM
Beside the measured number, compound 4's estimate is 2.1-fold (0.33 log units) above it; the measured number falls inside the stated range.
By their numbers in this assay, from the lowest: compounds 2 and 4 (each within the scatter of the next); then compounds 1 and 3 (each within the scatter of the next).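

In this assay, the step of a 1.5-fold higher number from compound 2 to compound 4 (0.17 log units; within the scatter) shows that the group hanging from the oxygen on the saturated ring carbon can change from 2-chlorobenzyl to 2-(4-methoxyphenyl)ethyl while the number stays within the scatter, so this position accepts more than one such group. The chlorine leaves, a methoxy enters and the chain grows in this single change, and the two compounds still read alike. Among the four compounds, the two with this oxygen have the lower numbers, with compound 2 at 47 nM and compound 4 at 70 nM against compound 1 at 2700 nM and compound 3 at 2930 nM, and no compound goes against this pattern, though no measurement at hand explains it.

Because those three features changed together, the compounds shown cannot separate what each contributes, and a plain 2-phenylethyl group or a longer chain such as 3-phenylpropyl would help to pull them apart. Going by these compounds, it also remains open whether the oxygen itself matters, which an amine nitrogen in its place could test.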